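This account rests on a few compounds, and the source may have more. Where it says the series, first, only, none or still open, it means among the compounds named here.

Measured so far in an assay on HEK293 cells for positive allosteric modulation of metabotropic glutamate receptor 5 (Homo sapiens), read by FLIPR; a higher number here means that more compound is needed for the effect, a lower number that less compound is needed:

compound 1 `O=C(c1ccc(F)cc1)N1CC(c2nc(-c3cccc(Cl)c3)no2)C1`: > 10000 nM, a limit of the assay and not a number
compound 2 `O=C(c1ccc(F)cc1)N1CC(c2nc(-c3cccc(F)c3)no2)C1`: 2400 nM

Compound 1 stands at the limit of > 10000 nM in this assay, at which 1 of the 2 values shown sits, so its position is known only as a limit, at the weak end of the pair. Within the data shown here, the one measured step in this assay is an at least 4.1-fold lower number from compound 1 to compound 2 (0.61 log units; beyond the scatter), a halogen swap on the aromatic ring.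

Compound 3 `CC1CN(C(=O)N2CC(c3nc(-c4cccc(Cl)c4)no3)C2)CC(C)O1` differs from compound 1 by 2,6-dimethylmorpholin-4-yl in place of 4-fluorophenyl on a carbonyl carbon. Among the measured compounds shown here, this change sits on the carbonyl carbon, a position the measured step does not touch, so no measured step bears on it and its direction cannot be read from the data. The starting point is itself only a limit.

Compound 3 is therefore estimated at 10000 nM, with a range from 2500 nM to 40000 nM. This estimate corresponds to an expected step of a number no higher from compound 1 to compound 3 (the limit leaves the size open), with a fair chance that this assay again reports only a limit for compound 3.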

Compound 3, half-maximal effective concentration: > 10000 nM
Compound 3 ended at the assay's limit (the forecaster's own chance of this, stated with the estimate: 50%); the middle value sits exactly at the limit.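

Compound 1 and compound 3 both give a limit of the assay and not a number, so no step between them can be read: the limit of > 10000 nM in this assay, at which 2 of the 3 values shown sit.

The compounds shown leave open whether 2,6-dimethylmorpholin-4-yl in place of 4-fluorophenyl on a carbonyl carbon changes the number at all, and whether fluoro in place of chloro would lower it in that setting too.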